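The compounds below may be only part of what the source reports. "The series", "measured", "known", "first", "only" and "open" are said of these compounds alone.

In a functional assay on RAW264.7 cells (Mus musculus) for inhibition, read by Griess assay, with stated times of 2 h and 24 h (on this read-out lower numbers stand for stronger inhibition and higher numbers for weaker inhibition), compound 1 `CCn1cc(COc2cc(O)c3c(c2)O[C@H](c2ccc(OC)c(O)c2)C/C3=N\O)nn1` gives 3140 nM, compound 2 `CCCCn1cc(COc2cc(O)c3c(c2)O[C@H](c2ccc(OC)c(O)c2)C/C3=N\O)nn1` gives 8900 nM, and compound 3 `COc1ccc([C@@H]2C/C(=N\O)c3c(O)cc(OCc4cn(C5CCCC5)nn4)cc3O2)cc1O` gives 6880 nM; compound 3 thus stands second highest of the three numbers, nearest to compound 2 and furthest from compound 1. Compound 4 `COc1ccc([C@@H]2C/C(=N\O)c3c(O)cc(OCc4cn(Cc5ccccc5Cl)nn4)cc3O2)cc1O` differs from compound 3 by 2-chlorobenzyl in place of cyclopentyl on an aromatic nitrogen. The measured steps that bear on this change are the two at the same aromatic nitrogen, a 2.2-fold higher number from compound 1 to compound 3 (0.34 log units; beyond the scatter) and a 1.3-fold lower number from compound 2 to compound 3 (0.11 log units; within the scatter), together with a 2.8-fold higher number from compound 1 to compound 2 (0.45 log units; beyond the scatter) elsewhere in the series. Changes at this nitrogen have so far given modestly higher numbers or nothing beyond the scatter, so only a small step in this assay, if any, is expected for compound 4. The estimate for compound 4 is 8000 nM, within 3500 nM to 18000 nM, meaning a 1.2-fold higher number from compound 3 to compound 4 (0.07 log units; within the scatter) is expected.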

Compound 4, half-maximal inhibitory concentration: 13400 nM
Compound 4: the middle estimate sits 1.7-fold (0.22 log units) below what was measured; the measured number falls inside the stated range.
By their numbers in this assay, from the lowest: compound 1; then compounds 3, 2 and 4 (each within the scatter of the next).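

In this assay, the first aromatic ring at this nitrogen, in the 2-chlorobenzyl group, gives a 1.9-fold higher number from compound 3 to compound 4 (0.29 log units; within the scatter) and a 1.5-fold higher number from compound 2 to compound 4 (0.18 log units; within the scatter), both within the scatter, so it stays level with cyclopentyl and butyl. Only the comparison with ethyl clears the scatter, with a 4.3-fold higher number from compound 1 to compound 4 (0.63 log units; beyond the scatter), the largest step at this nitrogen so far. No evidence on hand accounts for these steps.

Still open, going by these compounds, is what the chlorine contributes, which plain benzyl would test. Also open, on these data alone, is whether methyl, or a benzyl bearing an amine or a carboxylic acid, would fall below compound 1.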